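Trimming the Amide Substituent of Compound 1

The source may hold more compounds than are shown below. What is called first, only, known or untested is meant among the compounds shown, and "the series" means these compounds.

Going by the values given here, compound 1 `Cc1cccc2c1/C(=C/C(=O)NC1CC1)CC2` stands at the bottom of the two numbers measured so far. In a functional assay on the whole organism with Mus musculus as the target, at a dose of 100 mg/kg by the intraperitoneal route (a lower number here means less inhibition, a higher number more inhibition at the dose given (going by the name of the read-out)), compound 1 gives 17%, whereas compound 2 `CC(C)NC(=O)/C=C1\CCc2ccc(F)cc21` gives 100%, a gap well beyond the usual scatter. Compound 3 `Cc1cccc2c1/C(=C/C(N)=O)CC2` has not yet been tested. It differs from compound 1 by hydrogen in place of cyclopropyl on an amide-type nitrogen. Among the compounds with values here, no measured pair shows this change, so its effect rests on expectation alone. A modest rise, or no movement beyond the scatter, is the expected outcome, with the step of a number 13 percentage points higher from compound 1 to compound 3 (beyond the scatter) given as an estimate. Compound 3 is expected to reach about 30%, between 5% and 70%.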

Compound 3, a percentage reported as inhibition, in the whole organism at one dose (the size of the read-out at that dose, not a potency): 100%
Estimate against measurement, compound 3: 70 percentage points below, outside the stated range (above it).
By their numbers in this assay, from the lowest: compound 1; then compounds 2 and 3 (each within the scatter of the next).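

This position on the amide-type nitrogen strongly shapes the result: in this assay, hydrogen in place of cyclopropyl gives a number 83 percentage points higher from compound 1 to compound 3 (beyond the scatter) on the shared core. Going by these compounds alone, until now, no matched pair had isolated this change, so this is the first direct sign that the cyclopropyl group on this core carries a large penalty in the read-out. Nothing available explains why this change has so large an effect. Still open, on these data alone, is how a methyl or ethyl group on that nitrogen would read out. A single pair also cannot show whether the step holds on other cores.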